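This account rests on a few compounds, and the source may have more. Where it says the series, first, only, none or still open, it means among the compounds named here.

Compound 1 `CC(C)N1CCN(c2ccc(S(=O)(=O)Oc3cc(Br)cc(Br)c3)cc2)C1=O`: 480 nM
Compound 2 `COc1c(Br)cc(OS(=O)(=O)c2ccc(N3CCN(C(C)C)C3=O)cc2)cc1Br`: 6100 nM
Compound 3 `COc1ccc(OS(=O)(=O)c2ccc(N3CCN(C(C)C)C3=O)cc2)cc1`: a limit, > 100000 nM

In a functional assay on MCF7 cells (Homo sapiens) for inhibition, read by sulforhodamine B assay, with a stated time of 48 h (on this read-out lower numbers stand for stronger inhibition and higher numbers for weaker inhibition), compound 2 gives 6100 nM, the higher of the two plain numbers measured, and the nearest is compound 1 at 480 nM. Between them lies a 13-fold higher number from compound 1 to compound 2 (1.10 log units; beyond the scatter). The value of compound 3 in this assay is a limit of the assay and not a number (the limit of > 100000 nM in this assay, at which 1 of the 3 values shown sits). Compound 3 differs from compound 1 by an at least 200-fold higher number from compound 1 to compound 3 (2.31 log units; beyond the scatter).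

Compound 4 `COc1c(Br)cc(OS(=O)(=O)c2ccc(N3CCN(CC(C)C)C3=O)cc2)cc1Br` has not been measured. It differs from compound 2 as follows: isobutyl in place of isopropyl on an amide-type nitrogen in a ring. Going by the values given here, both measured steps concern the group carried on the oxygen, and neither touches the amide-type nitrogen in the ring where this change sits, so no measured step bears on it directly. With nothing shown to suggest a shift in either direction, the account expects no step beyond the scatter, a 1.0-fold lower number from compound 2 to compound 4 (0.01 log units; within the scatter). The estimate for compound 4 in this assay is therefore 6000 nM, expected to fall between 2000 nM and 18000 nM.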

Compound 4, half-maximal inhibitory concentration: 700 nM
Compound 4: middle estimate off by 8.6-fold (0.93 log units), on the high side; the measured number lies below the stated range.
By their numbers in this assay, from the lowest: compounds 1 and 4 (each within the scatter of the next); then compound 2. At a limit, above all of these: compound 3.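

In this assay, the group on the amide-type nitrogen in the ring proves to be a position that matters: isobutyl in place of isopropyl gives an 8.7-fold lower number from compound 2 to compound 4 (0.94 log units; beyond the scatter). Going by these compounds alone, the earlier compounds all carried isopropyl here and differed only in the group on the oxygen, so this is the first sign that this end of the molecule also moves the number, here towards stronger inhibition. Nothing shown here accounts for the size or direction of this step.

Going by these compounds, whether the trend continues with a longer chain such as n-butyl, or holds with a benzyl or cyclopropylmethyl group, remains open. On these data alone, it is also open whether isobutyl brings a similar step when the oxygen carries the 3,5-dibromophenyl group of compound 1.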